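The source may hold more compounds than are shown below. What is called first, only, known or untested is meant among the compounds shown, and "the series" means these compounds.

Compound 1 `O=S(=O)(c1ccccc1)c1c(OCCCCCCO)no[n+]1[O-]` offers no number to start from: in a functional assay on U-937 cells (Homo sapiens) for inhibition, read by MTT assay, with a stated time of 48 h (on this read-out lower numbers stand for stronger inhibition and higher numbers for weaker inhibition), compound 1 stands as "not determined" (no result reported). Compound 3 `O=C(CCCCOc1no[n+]([O-])c1S(=O)(=O)c1ccccc1)NO` differs from it by a single change at the chain end, (hydroxycarbamoyl in place of 2-hydroxyethyl on a saturated chain carbon, four bonds along the chain from an oxygen on an aromatic ring). Compound 2 `O=C(CCCOc1no[n+]([O-])c1S(=O)(=O)c1ccccc1)NO` also carries hydroxycarbamoyl, and in this assay compound 2 gives 3300 nM. Among the measured compounds shown here, with no value for compound 1, the size of the step in this assay cannot be worked out, so compound 2 is the only guide, and a reading for compound 3 within the usual scatter of that value is expected. For compound 3 the estimated value is 2500 nM, with an expected range of 800 nM to 7000 nM.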

Compound 3, half-maximal inhibitory concentration: 2910 nM
Estimate against measurement, compound 3: 1.2-fold (0.07 log units) below; low and high end bracket the measured number.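

Lengthening the chain, (hydroxycarbamoyl)methyl in place of hydroxycarbamoyl, gives a 1.1-fold lower number from compound 2 to compound 3 (0.05 log units; within the scatter) in this assay and so leaves the reading unchanged within the usual scatter. Over these two chain lengths, the exact distance of the hydroxycarbamoyl end from the core makes no measurable difference. Nothing measured here explains this result.

Compound 1 supplies no number, so the step from 2-hydroxyethyl to hydroxycarbamoyl cannot be read. From the compounds shown here alone, whether a carboxylic acid or an amine at the chain end, or a still longer chain, would read the same remains open.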